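Swapping the Furan of Compound 1 for 3-Methylphenyl

This account rests on a few compounds, and the source may have more. Where it says the series, first, only, none or still open, it means among the compounds named here.

In a functional assay on MDA-MB-231 cells (Homo sapiens) for cytotoxicity, read by MTT assay, with a stated time of 48 h (a lower number here means a stronger inhibitor, a higher number a weaker inhibitor), compound 1 `O=C(/C=C/c1ccc2c(c1)B(O)OC2)c1ccco1` gives 7300 nM, the highest of the two numbers recorded in this set. Compound 3 `O=C(/C=C/c1ccc2c(c1)B(O)OC2)c1ccc(Cl)c(Cl)c1` sits nearest with 3400 nM in this assay. Compound 2 `Cn1cccc1C(=O)/C=C/c1ccc2c(c1)B(O)OC2` gives > 100000 nM in this assay, which is a limit of the assay and not a number. Among the compounds with values here, the only measured step that changes the same part of the molecule is an at least 13-fold higher number from compound 1 to compound 2 (1.13 log units; beyond the scatter), and its size is known only because of the limit of > 100000 nM in this assay, at which 1 of the 3 values shown sits.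

Compound 4 `Cc1cccc(C(=O)/C=C/c2ccc3c(c2)B(O)OC3)c1` has not yet been measured in this assay. It differs from compound 1 in that (3-methylphenyl in place of furan-2-yl on a carbonyl carbon). Within the data shown here, the one measured step on the carbonyl carbon ran toward a far higher number, but the values of compound 1 and compound 3 show that a six-membered aromatic ring of carbon only at this position can give the lower of the two numbers. Compound 4 is therefore expected to land near compound 3. The step of a 1.6-fold lower number from compound 1 to compound 4 (0.21 log units; within the scatter) is estimated to be small, toward a lower number, within or just beyond the scatter. The estimate for compound 4 is 4500 nM, with a range from 1500 nM to 15000 nM.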

Compound 4, half-maximal inhibitory concentration: 4500 nM
Compound 4: the middle estimate sits on the measured number at the digits printed, and the stated range covers the measured number.
By their numbers in this assay, from the lowest: compounds 3, 4 and 1 (each within the scatter of the next, the first and the last beyond it). At a limit, above all of these: compound 2.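

Exchanging furan-2-yl for 3-methylphenyl on the carbonyl carbon gives a 1.6-fold lower number from compound 1 to compound 4 (0.21 log units; within the scatter) in this assay. This position therefore carries a five-membered aromatic ring with one hetero atom and a six-membered aromatic ring of carbon only with no step beyond the scatter, even though the change removes the hydrogen-bond acceptor counted on furan-2-yl. Among the groups shown, only 1-methyl-1H-pyrrol-2-yl stands apart, with an at least 22-fold lower number from compound 2 to compound 4 (1.34 log units; beyond the scatter), and the size of that step is known only through a limit: the limit of > 100000 nM in this assay, at which 1 of the 4 values shown sits.

On these data alone, it remains open whether an unsubstituted phenyl group at this place would give a number close to that of compound 4. Also open, as far as these compounds go, is what an amine or a carboxylic acid in place of the methyl of compound 4 would do in this assay.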